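Benzoyl on the Aniline Nitrogen of a Chalcone

The compounds below may be only part of what the source reports. "The series", "measured", "known", "first", "only" and "open" are said of these compounds alone.

Measured compounds:
compound 1, `Nc1ccc(C(=O)/C=C/c2ccco2)cc1`: 24000 nM
compound 2, `Nc1ccc(C(=O)/C=C/c2ccccc2)cc1`: 23000 nM

Both compounds were tested in a functional assay on HCT-116 cells (Homo sapiens) for cytotoxicity, read by resazurin assay, with a stated time of 48 h; on this read-out lower numbers stand for an effect already at smaller amounts and higher numbers for an effect only at larger amounts of compound. Compound 2 carries the lowest of the two numbers, yet its value and that of compound 1 lie within the usual scatter of each other, so nothing separates them.

Compound 3, `O=C(/C=C/c1ccccc1)c1ccc(NC(=O)c2ccccc2)cc1`, has not yet been measured in this assay. It differs from compound 2 in one place: benzoyl in place of hydrogen on a nitrogen on an aromatic ring. Going by the values given here, no pair of measured compounds shows what such a change does here, so the size of the step cannot be read from any measured pair. Among the compounds with values here, with only two compounds at hand, and those two indistinguishable, the expectation rests on the structural change alone. A step toward a lower number in this assay is expected, of moderate size, with a real chance that it stays within the scatter.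

Compound 3 is therefore estimated at 12000 nM, with a range from 3000 nM to 40000 nM. This corresponds to an expected step of a 1.9-fold lower number from compound 2 to compound 3 (0.28 log units; within the scatter).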

Compound 3, half-maximal effective concentration: 28000 nM
Compound 3: middle estimate off by 2.3-fold (0.37 log units), on the low side; measured number inside the range.
By their numbers in this assay, from the lowest: compounds 2, 1 and 3 (each within the scatter of the next).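

In this assay, going by these compounds alone, putting benzoyl in place of hydrogen on a nitrogen on an aromatic ring gives a 1.2-fold higher number from compound 2 to compound 3 (0.09 log units; within the scatter), the first step at this position that can be read from measured compounds. This one step shows that the nitrogen on the aromatic ring can carry benzoyl, with its 8 heavy atoms and additional six-membered aromatic ring, while compound 3 stays within the scatter of compound 2, so this change does not separate the two compounds in this cell assay. Nothing shown here offers an explanation for that outcome, and a single pair sets no rule for this position.

As far as these compounds go, it remains open whether a smaller group on the same nitrogen, such as acetyl or methyl, or a larger change, such as a carboxylic acid or an amine carried on the added benzoyl ring, would produce a step beyond the scatter. From the compounds shown here alone, it is also open whether benzoyl on the corresponding nitrogen of compound 1 would leave that compound within the scatter in the same way.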